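The source may report more compounds than this note shows. Statements on the series, on what has been measured and on what is new or still open speak of the compounds shown alone.

Measured so far:
compound 1, `Oc1cccc(-c2cc(-c3ccc(F)cc3)cc(-c3cccc(O)c3)n2)c1`: 1280 nM
compound 2, `Oc1cccc(-c2cc(-c3cccc(C(F)(F)F)c3)cc(-c3ccccc3O)n2)c1`: 19500 nM

In a functional assay on HeLa cells (Homo sapiens) for inhibition (on this read-out higher numbers stand for weaker inhibition and lower numbers for stronger inhibition), compound 1 gives 1280 nM. Compound 2 gives 19500 nM in this assay, the higher of the two numbers by a gap beyond the scatter, so compound 2 stands as the weaker inhibitor of the pair.

Compound 3, `Oc1cccc(-c2cc(-c3cccc(C(F)(F)F)c3)cc(-c3cccc(O)c3)n2)c1`, is not yet measured. It differs from compound 2 by 3-hydroxyphenyl in place of 2-hydroxyphenyl on an aromatic carbon. After this change compound 3 carries two 3-hydroxyphenyl groups on its core, the same pair that compound 1 carries. Going by the values given here, no step between measured compounds matches this change, so the expectation rests on compound 1 with its two 3-hydroxyphenyl groups giving 1280 nM in this assay.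

Compound 3 is therefore expected to move toward a lower number in this assay, an expected step of a 6.5-fold lower number from compound 2 to compound 3 (0.81 log units; beyond the scatter). The estimate for compound 3 in this assay is 3000 nM, with a range from 800 nM to 12000 nM.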

Compound 3, half-maximal inhibitory concentration: 12700 nM
Compound 3: middle estimate off by 4.2-fold (0.63 log units), on the low side; measured number above the stated range.
By their numbers in this assay, from the lowest: compound 1; then compounds 3 and 2 (each within the scatter of the next).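

With 3-hydroxyphenyl in place of 2-hydroxyphenyl next to the ring nitrogen, this assay shows a 1.5-fold lower number from compound 2 to compound 3 (0.19 log units; within the scatter) and so does not separate these two compounds while the 3-(trifluoromethyl)phenyl group is present. Going by these compounds alone, the first direct reading at the other aryl position, 3-(trifluoromethyl)phenyl in place of 4-fluorophenyl, gives a 9.9-fold higher number from compound 1 to compound 3 (1.00 log units; beyond the scatter) with both 3-hydroxyphenyl groups held constant, so in this small set the clear step lies at that position and not at the hydroxyl placement. No measurement at hand bears on the reason for either step.

On these data alone, the 2-hydroxyphenyl group appears only together with 3-(trifluoromethyl)phenyl, so its effect alongside 4-fluorophenyl remains open. Also open, as far as these compounds go, is how a methoxy group, an amine or a carboxylic acid would read in place of the hydroxyl group.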